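Methoxy shift on the benzyl group of compound 3

This account rests on a few compounds, and the source may have more. Where it says the series, first, only, none or still open, it means among the compounds named here.

Measured so far in a functional assay on NCI-H1299 cells (Homo sapiens) for antiproliferative activity, read by fluorescence and resazurin assay, with a stated time of 48 h; on this read-out higher numbers stand for weaker inhibition and lower numbers for stronger inhibition:
- compound 1 `COc1ccc(Cn2cc(-c3ccc(O)cc3)c(-c3ccc(O)cc3)c2)cc1` gives 37300 nM
- compound 2 `COc1ccc(-c2cn(Cc3ccc(O)c(O)c3)cc2-c2ccc(OC)cc2)cc1` gives 19100 nM
- compound 3 `COc1ccc(Cn2cc(-c3ccc(O)c(O)c3)c(-c3ccc(O)c(O)c3)c2)cc1` gives 8300 nM

Compound 3 has the lowest of the three numbers, and its gaps to compound 2 and compound 1 both lie beyond the scatter. Compound 4 `COc1ccccc1Cn1cc(-c2ccc(O)c(O)c2)c(-c2ccc(O)c(O)c2)c1` has the same atoms joined differently, with 2-methoxyphenyl in place of 4-methoxyphenyl on a saturated chain carbon bound to an aromatic nitrogen. Among the compounds with values here, no measured pair isolates this change, so no direct precedent exists. In this assay no step beyond the scatter is expected, and neither direction is favoured. The expected change is small (a 1.1-fold higher number from compound 3 to compound 4 (0.04 log units; within the scatter)). For compound 4 the estimated value is 9000 nM (expected range 4000 nM to 20000 nM).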

Compound 4, half-maximal inhibitory concentration: 8600 nM
Compound 4: the middle estimate sits 1.0-fold (0.02 log units) above what was measured, and the stated range covers the measured number.
By their numbers in this assay, from the lowest: compounds 3 and 4 (each within the scatter of the next); then compounds 2 and 1 (each within the scatter of the next).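

In this assay, within the data shown here, the change from 4-methoxybenzyl to 2-methoxybenzyl gives a 1.0-fold higher number from compound 3 to compound 4 (0.02 log units; within the scatter) and provides the first measured pair that differs in one place. On this core, the methoxy group can therefore occupy either of these two ring positions without a change beyond the scatter. No supporting evidence bears on this result.

On these data alone, whether an amine or a carboxylic acid in place of the methoxy group would give a similar reading remains open. As far as these compounds go, it is also open whether the same methoxy shift would read alike with the phenol-bearing aryl groups of compound 1.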